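Chloro for fluoro: from compound 3 to compound 4

A few compounds are considered here, and "the series" means these few. Any claim that something is new, unique, unknown or untested is made for them only; others in the source may bear on it.

Compound 1 `Cc1c(C(=O)Nc2ccc(Oc3ccnc4[nH]ccc34)c(F)c2)nnn1-c1ccc(F)cc1` gives 150 nM in a functional assay on A549 cells (Homo sapiens) for cytotoxicity, read by MTT assay, with a stated time of 72 h; a lower number here means a stronger inhibitor, a higher number a weaker inhibitor. Compound 2 `COc1ccc(-n2nnc(C(=O)Nc3ccc(Oc4ccnc5[nH]ccc45)c(F)c3)c2C)cc1` gives 710 nM in this assay, and compound 3 `Cc1c(C(=O)Nc2ccc(Oc3ccnc4[nH]ccc34)c(F)c2)nnn1-c1ccc(F)c(F)c1` gives 570 nM. Compound 3 thus stands second highest of the three numbers: its nearest neighbour is shown by a 1.2-fold lower number from compound 2 to compound 3 (0.10 log units; within the scatter), within the scatter, and its furthest by a 3.8-fold higher number from compound 1 to compound 3 (0.58 log units; beyond the scatter), beyond it. Compound 4 `Cc1c(C(=O)Nc2ccc(Oc3ccnc4[nH]ccc34)c(F)c2)nnn1-c1ccc(F)c(Cl)c1` differs from compound 3 by chloro in place of fluoro on an aromatic carbon. Going by the values given here, no measured step exchanges chloro for fluoro; the only precedents, a 3.8-fold higher number from compound 1 to compound 3 (0.58 log units; beyond the scatter) and a 4.7-fold higher number from compound 1 to compound 2 (0.68 log units; beyond the scatter), concern other substituent changes and were both modest. A step of the size a 1.1-fold lower number from compound 3 to compound 4 (0.06 log units; within the scatter) is therefore expected for compound 4, within the scatter. Compound 4 is estimated to give 500 nM, between 200 nM and 1200 nM.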

Compound 4, half-maximal inhibitory concentration: 730 nM
Compound 4: the middle estimate sits 1.5-fold (0.16 log units) below what was measured; measured number inside the range.
By their numbers in this assay, from the lowest: compound 1; then compounds 3, 2 and 4 (each within the scatter of the next).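

In this assay, chloro and fluoro read alike on this aromatic carbon (a 1.3-fold higher number from compound 3 to compound 4 (0.11 log units; within the scatter)), and the 3-chloro-4-fluorophenyl group reads alike with 4-methoxyphenyl (a 1.0-fold higher number from compound 2 to compound 4 (0.01 log units; within the scatter)). Against hydrogen at the same place, chloro gives a modest step (a 4.9-fold higher number from compound 1 to compound 4 (0.69 log units; beyond the scatter)), as fluoro did (a 3.8-fold higher number from compound 1 to compound 3 (0.58 log units; beyond the scatter)). Nothing at hand explains these readings.

Open, from the compounds shown here alone, is whether an amine, a carboxylic acid or trifluoromethyl on this carbon would also read alike with chloro and fluoro. Also open, going by these compounds, is whether any group here can reach the number of compound 1 (150 nM).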